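Neopentyl ketone in place of the tert-butyl urea

The source may hold more compounds than are shown below. What is called first, only, known or untested is meant among the compounds shown, and "the series" means these compounds.

Compound 2 `CCCS(=O)(=O)N1CCN(c2ccc(OCC3CCN(C(=O)NC(C)(C)C)CC3)cn2)CC1` gives 800 nM in a functional assay on CHO-K1 cells for agonist activity at Glucose-dependent insulinotropic receptor (Homo sapiens), read by a luciferase reporter, with a stated time of 5 h (on this read-out lower numbers stand for an effect already at smaller amounts and higher numbers for an effect only at larger amounts of compound), and holds the lowest of the two numbers recorded so far; compound 1 `CCCS(=O)(=O)N1CCN(c2ccc(OCC3CCN(C(=O)CC(C)C)CC3)cn2)CC1` is nearest at 1600 nM, a gap within the scatter. Compound 3 `CCCS(=O)(=O)N1CCN(c2ccc(OCC3CCN(C(=O)CC(C)(C)C)CC3)cn2)CC1` has not yet been measured. Its change from compound 2 reads (neopentyl in place of (tert-butyl)amino on a carbonyl carbon). Within the data shown here, the only measured step bearing on it is a 2.0-fold lower number from compound 1 to compound 2 (0.30 log units; within the scatter), which exchanged an alkyl chain on the carbonyl carbon for an amino group and moved the number by an amount inside the scatter. Compound 3 returns to an alkyl chain on that carbonyl carbon, so a step of similar size in the reverse direction, or none beyond the scatter, is expected: a 1.5-fold higher number from compound 2 to compound 3 (0.18 log units; within the scatter). For compound 3 a value near 1200 nM is estimated, with a range from 500 nM to 3000 nM.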

Compound 3, half-maximal effective concentration: 2800 nM
Beside the measured number, compound 3's estimate is 2.3-fold (0.37 log units) below it; low and high end bracket the measured number.
By their numbers in this assay, from the lowest: compounds 2, 1 and 3 (each within the scatter of the next, the first and the last beyond it).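

In this assay, the exchange on the carbonyl carbon now gives a step beyond the scatter: a 3.5-fold higher number from compound 2 to compound 3 (0.54 log units; beyond the scatter). Neopentyl carries no hydrogen-bond donor where (tert-butyl)amino carries one, yet compound 2 is separated only from compound 3, as its step to compound 1 stays within the scatter. The methyl that distinguishes neopentyl from isobutyl reads as a 1.8-fold higher number from compound 1 to compound 3 (0.24 log units; within the scatter), so these two alkyl groups cannot be told apart at this position.

No available measurement accounts for the step. The compounds shown leave open whether the nitrogen itself or the tert-butyl group attached to it matters, and a tert-butoxy group, a methylamino group or a plain amino group on the same carbonyl carbon would bear on that question.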